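Swapping the benzyl substituent on a weak antiproliferative lead

A few compounds are considered here, and "the series" means these few. Any claim that something is new, unique, unknown or untested is made for them only; others in the source may bear on it.

Measured so far:
- compound 1, `COc1cccc(CNC(=O)c2cccc(C(C)Oc3cccnc3Nc3cnn(C)c3)c2)c1`: 49400 nM
- compound 2, `CC(Oc1cccnc1Nc1cnn(C)c1)c1cccc(C(=O)NCc2ccc(OC(F)(F)F)cc2)c1`: 8300 nM

Of the compounds shown here, two sharing one core have been tested in a functional assay on NCI-H3122 cells (Homo sapiens) for antiproliferative activity, read by MTT assay, with a stated time of 48 h; a higher number here means a weaker inhibitor, a lower number a stronger inhibitor. Compound 1 gives 49400 nM in this assay, and compound 2 gives 8300 nM. Within the data shown here, the only structural step between them, a 4-(trifluoromethoxy)phenyl in place of a 3-methoxyphenyl on a saturated chain carbon bound to an amide-type nitrogen, produced a 6.0-fold lower number from compound 1 to compound 2 (0.77 log units; beyond the scatter). Compound 2 thus holds the lowest number of the two, with compound 1 the nearest neighbour at a clearly higher value.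

Compound 3, `CC(Oc1cccnc1Nc1cnn(C)c1)c1cccc(C(=O)NCc2ccc(F)c(Cl)c2)c1`, has not yet been measured in this assay. It differs from compound 2 in one place: 3-chloro-4-fluorophenyl in place of 4-(trifluoromethoxy)phenyl on a saturated chain carbon bound to an amide-type nitrogen. Among the measured compounds shown here, the only measured step that bears on this region is the one from compound 1 to compound 2, which shows that changing the group on this benzyl carbon can move the number by a modest amount in either direction. For the measured compounds named here, no measured pair contains a 3-chloro-4-fluorophenyl, so the direction is uncertain. A step in this assay of about a 1.4-fold lower number from compound 2 to compound 3 (0.14 log units; within the scatter) is therefore expected. Compound 3 is estimated at 6000 nM, within a range from 2000 nM to 20000 nM.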

Compound 3, half-maximal inhibitory concentration: 35700 nM
Compound 3: middle estimate off by 6.0-fold (0.77 log units), on the low side; measured number outside the range, above it.
By their numbers in this assay, from the lowest: compound 2; then compounds 3 and 1 (each within the scatter of the next).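

In this assay, putting 3-chloro-4-fluorophenyl on the saturated chain carbon bound to the amide-type nitrogen gave a 4.3-fold higher number from compound 2 to compound 3 (0.63 log units; beyond the scatter), so the gain seen with 4-(trifluoromethoxy)phenyl does not carry over to every phenyl group containing fluorine. Replacing 3-methoxyphenyl with 3-chloro-4-fluorophenyl gave a 1.4-fold lower number from compound 1 to compound 3 (0.14 log units; within the scatter), so these two groups cannot be told apart here, and of the three groups shown, only 4-(trifluoromethoxy)phenyl stands clearly apart from both others. The data at hand offer no explanation for why this position responds in this way.

The three phenyl groups differ both in the substituents they carry and in the ring numbers at which they carry them, so the compounds shown cannot separate the identity of a substituent from its place on the ring. Going by these compounds, it remains open how an unsubstituted phenyl, a 3-(trifluoromethoxy)phenyl or a 4-chlorophenyl would compare at this position, and whether a longer chain carrying the ring would keep the advantage of compound 2.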